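Lengthening the triazole side chain with a dimethylamino group

The compounds below may be only part of what the source reports. "The series", "measured", "known", "first", "only" and "open" are said of these compounds alone.

Compound 1 `Cn1cnnc1-c1cc(Oc2ccc(NC(=O)Nc3cccc(C(F)(F)F)c3)cc2F)ccn1`: 6470 nM
Compound 2 `CCN(CC)CCn1cnnc1-c1cc(Oc2ccc(NC(=O)Nc3ccccc3C(F)(F)F)cc2F)ccn1`: 11600 nM

In a functional assay on MDA-MB-231 cells (Homo sapiens) for antiproliferative activity, read by MTT assay, with a stated time of 72 h (on this read-out higher numbers stand for weaker inhibition and lower numbers for stronger inhibition), compound 1 gives 6470 nM and compound 2 gives 11600 nM; these two numbers sit within the usual scatter of each other, so neither stands out. Compound 3 `CN(C)CCCn1cnnc1-c1cc(Oc2ccc(NC(=O)Nc3cccc(C(F)(F)F)c3)cc2F)ccn1` differs from compound 1 by 2-(dimethylamino)ethyl in place of hydrogen on a saturated chain carbon bound to an aromatic nitrogen, so the methyl on the shared core becomes a 3-(dimethylamino)propyl chain. Among the measured compounds shown here, no measured pair shows this kind of change, so compound 3 is expected to stay close to compound 1, with a step from a 1.2-fold higher number from compound 1 to compound 3 (0.09 log units; within the scatter) of modest size at most, not clearly beyond the scatter. Compound 3 is therefore estimated at 8000 nM, with a range of 3000 nM to 22000 nM.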

Compound 3, half-maximal inhibitory concentration: 13300 nM
The estimate for compound 3 lay 1.7-fold (0.22 log units) below the measured number; measured number inside the range.
By their numbers in this assay, from the lowest: compounds 1, 2 and 3 (each within the scatter of the next, the first and the last beyond it).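

Among the compounds shown here, this is the only step here that changes one place on the shared core. In this assay the move from methyl to 3-(dimethylamino)propyl gives a 2.1-fold higher number from compound 1 to compound 3 (0.31 log units; beyond the scatter) and so a modest weakening, which means this position tolerates the longer chain but gains nothing from it. No measurement here gives a reason for this step.

On these data alone, whether the chain length or its dimethylamino end drives the change stays open, since a plain propyl chain would separate the two. A morpholine or a carboxylic acid at the chain end could also behave differently.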